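A few compounds are considered here, and "the series" means these few. Any claim that something is new, unique, unknown or untested is made for them only; others in the source may bear on it.

Measured compounds:
- compound 1 `CC[C@@H]1C(=O)N(C)c2cnc(-n3ccc4cc(C(N)=O)ccc43)nc2N1C1CCCC1`: 28.5 nM
- compound 2 `CC[C@@H]1C(=O)N(C)c2cnc(-n3ccc4ccccc43)nc2N1C1CCCC1`: 355 nM
- compound 3 `CC[C@@H]1C(=O)N(C)c2cnc(-n3ccc4cc(F)ccc43)nc2N1C1CCCC1`: 969 nM

The three share one core and differ only at one aromatic carbon of the fused two-ring system. In an assay for inhibition of serine/threonine-protein kinase PLK2 (Homo sapiens), read by FRET and Z'-LYTE, with a stated time of 1 h (a lower number here means a stronger inhibitor, a higher number a weaker inhibitor), compound 3 gives the highest number of the three: a 2.7-fold higher number from compound 2 to compound 3 (0.44 log units; beyond the scatter), and a 34-fold higher number from compound 1 to compound 3 (1.53 log units; beyond the scatter). Compound 1, carrying carbamoyl at that carbon, gives the lowest number, and removing it costs a lot: a 12-fold higher number from compound 1 to compound 2 (1.10 log units; beyond the scatter).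

Compound 4 `CC[C@@H]1C(=O)N(C)c2cnc(-n3ccc4cc(C(=O)NC(C)C)ccc43)nc2N1C1CCCC1` is not yet measured. The change from compound 3 is isopropylcarbamoyl in place of fluoro on an aromatic carbon. The step that bears most directly on it is the reverse of the change from compound 1 to compound 3, since compound 4 carries an amide at the same carbon, differing from compound 1 only by the isopropyl on the amide nitrogen. A large drop in the number is therefore expected for compound 4, of roughly the size of a 34-fold higher number from compound 1 to compound 3 (1.53 log units; beyond the scatter) run backwards, though whether the isopropyl adds or takes away is not known from these three compounds. Compound 4 is estimated at 40 nM (range 12 nM to 150 nM), a step of a 24-fold lower number from compound 3 to compound 4 (1.38 log units; beyond the scatter) expected in this assay.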

Compound 4, half-maximal inhibitory concentration: 17.4 nM
The estimate for compound 4 lay 2.3-fold (0.36 log units) above the measured number, within the range that was stated.
By their numbers in this assay, from the lowest: compounds 4 and 1 (each within the scatter of the next); then compound 2; then compound 3.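

Isopropyl on the amide nitrogen leaves the number within the scatter (a 1.6-fold lower number from compound 1 to compound 4 (0.21 log units; within the scatter)), so compound 4 and compound 1 cannot be ordered in this assay, and this position accepts a larger group on the amide nitrogen than the carbamoyl of compound 1 carries. The large advantage of an amide at this carbon persists with the substituted amide, both over hydrogen (a 20-fold lower number from compound 2 to compound 4 (1.31 log units; beyond the scatter)) and over fluoro (a 56-fold lower number from compound 3 to compound 4 (1.75 log units; beyond the scatter)), so it does not require both amide hydrogens. No supporting measurement accounts for these steps.

Still open, as far as these compounds go, is how far the amide nitrogen tolerates further growth, as with a longer chain, a cyclopropyl group or a dimethylcarbamoyl group that lacks the amide hydrogen. Also open, from the compounds shown here alone, is whether the carbonyl alone suffices, as would be tested by an acetyl group, or whether a carboxylic acid or a nitrile can stand in for the amide.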